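From Compound 1 to Compound 4: a Polar Replacement

A few compounds are considered here, and "the series" means these few. Any claim that something is new, unique, unknown or untested is made for them only; others in the source may bear on it.

Compound 1 `COc1cc(NC(C)CCCNC(=O)Nc2ccc(Cl)c(C(F)(F)F)c2)c2ncccc2c1` gives 3100 nM in a functional assay on CCRF-CEM cells (Homo sapiens) for inhibition, read by MTT assay, with a stated time of 4 days (a lower number here means a stronger inhibitor, a higher number a weaker inhibitor), the lowest of the three numbers recorded here. Compound 3 `COc1cc(NC(C)CCCNC(=O)NNC(=O)NCCCC(C)Nc2cc(OC)cc3cccnc23)c2ncccc2c1` gives 87000 nM in this assay, and compound 2 `O=C(NC(c1ccccc1)c1ccc(Cl)cc1)n1nnc2ccccc21` gives 116000 nM; both gaps to compound 1 lie beyond the usual scatter. Compound 4 `COc1cc(NC(C)CCCNC(=O)NNC(=O)NC(CO)(CO)CO)c2ncccc2c1` has not yet been measured. It differs from compound 1 in one place: ((2-hydroxy-1,1-bis(hydroxymethyl)ethyl)carbamoyl)amino in place of 4-chloro-3-(trifluoromethyl)phenyl on an amide-type nitrogen. Within the data shown here, no measured pair shows this exact change, so the expectation rests on the spread of the recorded values, where compound 3 gives 87000 nM. The step of a 26-fold higher number from compound 1 to compound 4 (1.41 log units; beyond the scatter) is estimated as a large rise in the number. Compound 4 is therefore expected to give about 80000 nM, within a range from 20000 nM to 300000 nM.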

Compound 4, half-maximal inhibitory concentration: > 250000 nM
Compound 4: no number, only a limit (the forecaster's own chance of this, stated with the estimate: 25%); at least 3.1-fold (0.49 log units) between middle value and limit.
By their numbers in this assay, from the lowest: compound 1; then compounds 3 and 2 (each within the scatter of the next). At a limit, above all of these: compound 4.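

On the amide-type nitrogen of compound 1, putting ((2-hydroxy-1,1-bis(hydroxymethyl)ethyl)carbamoyl)amino in place of 4-chloro-3-(trifluoromethyl)phenyl gives an at least 80-fold higher number from compound 1 to compound 4 (1.90 log units; beyond the scatter) in this assay. Compound 4 has a limit, not a number: the limit of > 250000 nM in this assay, at which 1 of the 4 values shown sits. Among these compounds, this is the only pair here differing in one place, so it alone ties a large rise in the number to this position.

A single pair cannot separate losing the chloro and trifluoromethyl substituents from losing the aromatic ring. On these data alone, how an unsubstituted phenyl or a 4-chlorophenyl group would read at this nitrogen remains open.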